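Replacing 3,4-dichlorophenyl with 4-nitrophenyl on the amide nitrogen

A few compounds are considered here, and "the series" means these few. Any claim that something is new, unique, unknown or untested is made for them only; others in the source may bear on it.

Compounds measured so far:
Compound 1 `O=C(/C=C/C(=O)N1C/C(=C\c2ccccc2)C(=O)/C(=C/c2ccccc2)C1)Nc1ccc(Cl)c(Cl)c1`: 350 nM
Compound 2 `Cc1cccc(C)c1NC(=O)/C=C/C(=O)N1C/C(=C\c2ccccc2)C(=O)/C(=C/c2ccccc2)C1`: 7400 nM
Compound 3 `O=C(/C=C/C(=O)N1C/C(=C\c2ccc([N+](=O)[O-])cc2)C(=O)/C(=C/c2ccc([N+](=O)[O-])cc2)C1)Nc1ccc(Cl)c(Cl)c1`: 380 nM

In a functional assay on CCRF-CEM cells (Homo sapiens) for cytotoxicity (a lower number here means a stronger inhibitor, a higher number a weaker inhibitor), compound 3 sits second highest of the three numbers. Compound 1 is its nearest neighbour, and the two values lie within the scatter of each other; compound 2 stands furthest away, with a number beyond the scatter.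

Compound 4 `O=C(/C=C/C(=O)N1C/C(=C\c2ccc([N+](=O)[O-])cc2)C(=O)/C(=C/c2ccc([N+](=O)[O-])cc2)C1)Nc1ccc([N+](=O)[O-])cc1` has not yet been measured. It differs from compound 3 in one place: 4-nitrophenyl in place of 3,4-dichlorophenyl on an amide-type nitrogen.

Within the data shown here, only one measured step changes the group on that same amide nitrogen, and it is a 21-fold higher number from compound 1 to compound 2 (1.33 log units; beyond the scatter). That step shows the aryl group on the amide nitrogen can shift the number strongly. It does not, however, concern 4-nitrophenyl, and the pair of compound 1 and compound 3 shows that nitro groups elsewhere on the shared core changed the number only within the scatter. The step from compound 3 to compound 4 is therefore expected to be uncertain in size; a modest rise is estimated, a 2.1-fold higher number from compound 3 to compound 4 (0.32 log units; beyond the scatter), but with a wide range.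

Compound 4 is estimated at 800 nM, between 200 nM and 4000 nM.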

Compound 4, half-maximal inhibitory concentration: 410 nM
Beside the measured number, compound 4's estimate is 2.0-fold (0.29 log units) above it, and the stated range covers the measured number.
By their numbers in this assay, from the lowest: compounds 1, 3 and 4 (each within the scatter of the next); then compound 2.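

In this assay the exchange of 3,4-dichlorophenyl for 4-nitrophenyl on the amide-type nitrogen gives a 1.1-fold higher number from compound 3 to compound 4 (0.03 log units; within the scatter), so this aryl change leaves the number within the scatter. The only earlier step at this nitrogen, a 21-fold higher number from compound 1 to compound 2 (1.33 log units; beyond the scatter), had shown that the aryl group there can shift the number strongly; the new step shows that not every exchange of that group does. A 4-nitrophenyl group, with its 2 hydrogen-bond acceptors, stands in for a 3,4-dichlorophenyl group with none and gives a number within the scatter of the original, although this step was read on the nitro-bearing core of compound 3 and the larger step on the core of compound 1. Nothing in the data shown accounts for this result.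

The compounds shown leave open whether 2,6-dimethylphenyl on the nitro-bearing core would bring a step of similar size to the one seen on the core of compound 1. They also leave open whether an aryl group carrying an amine or a carboxylic acid, or a saturated cyclohexyl ring on this nitrogen, would keep the number in the same range.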